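The compounds below may be only part of what the source reports. "The series", "measured", "known", "first", "only" and "open" are said of these compounds alone.

Measured so far:
compound 1 `COc1cc(C(=O)O)ccc1OCCCCOc1ccc(C(=O)CC(C)(C)C)c(O)c1C` — 47 nM
compound 2 `Cc1c(OCCCCOc2ccc(C(=O)O)cc2Cl)ccc(C(=O)CC2CCCC2)c1O` — 237 nM
compound 3 `Cc1c(OCCCCOc2ccc(C(=O)CC(C)(C)C)c(O)c2C)cccc1C(=O)O` — 136 nM

Of the compounds shown here, three have been read in an assay on HEK293 cells for positive allosteric modulation of metabotropic glutamate receptor 2 (Rattus norvegicus), read by thallium flux, with a stated time of 2.5 min; on this read-out higher numbers stand for an effect only at larger amounts of compound and lower numbers for an effect already at smaller amounts. In this assay compound 2 gives 237 nM, the highest of the three numbers. Compound 3, which gives 136 nM, sits within the usual scatter of compound 2, so the two cannot be ranked against each other. Compound 1, which gives 47 nM, lies beyond the scatter from compound 2, so its effect appears at smaller amounts of compound than does that of compound 2.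

The step of interest leads from compound 2 to compound 4 `COc1ccc(C(=O)O)cc1OCCCCOc1ccc(C(=O)CC2CCCC2)c(O)c1C`, which has not yet been measured in this assay. The structural change is 5-carboxy-2-methoxyphenyl in place of 4-carboxy-2-chlorophenyl on an oxygen on a saturated carbon. The aryl group that enters is the same one that compound 1 carries, while the ketone side of compound 4 is that of compound 2.

Among the measured compounds shown here, no step between measured compounds has been tabulated, so the expectation rests on the values alone. Because compound 1 gives 47 nM with this aryl group, the step is expected to run downward, toward smaller amounts, and to exceed the scatter: a 3.2-fold lower number from compound 2 to compound 4 (0.50 log units; beyond the scatter). Compound 4 is therefore estimated at 75 nM, with a likely range from 25 nM to 220 nM.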

Compound 4, half-maximal effective concentration: 425 nM
Compound 4: the middle estimate sits 5.7-fold (0.75 log units) below what was measured; measured number outside the range, above it.
By their numbers in this assay, from the lowest: compound 1; then compounds 3, 2 and 4 (each within the scatter of the next, the first and the last beyond it).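

In this assay the exchange of 4-carboxy-2-chlorophenyl for 5-carboxy-2-methoxyphenyl on an oxygen on a saturated carbon gives a 1.8-fold higher number from compound 2 to compound 4 (0.25 log units; within the scatter), so with the ketone side of compound 2 these two aryl groups cannot be told apart. Compound 4 carries the same aryl group as compound 1 and differs from it only on the ketone side, yet compound 1 gives 47 nM and compound 4 gives 425 nM, a gap beyond the scatter, which shows that this aryl group does not bring the low number of compound 1 with it on every ketone side. The data at hand offer no explanation for this result.

As far as these compounds go, it remains open how 4-carboxy-2-chlorophenyl would read on the ketone side of compound 1, a value that would show whether the aryl group and the ketone side act independently of each other. Also open, from the compounds shown here alone, is how the numbers would move with a tetrazole in place of the carboxylic acid, or with a longer chain in place of the saturated chain of compound 4.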